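The source may hold more compounds than are shown below. What is called first, only, known or untested is meant among the compounds shown, and "the series" means these compounds.

Measured in a functional assay on A549 cells (Homo sapiens) for antiproliferative activity, read by luminescence and CellTiter-Glo, with a stated time of 48 h; a higher number here means a weaker inhibitor, a lower number a stronger inhibitor:
- Compound 1 `COc1ccc(/C=C/[C@H]2CC=CC(=O)O2)cc1`: > 100000 nM, a limit
- Compound 2 `O=C1C=CC[C@H](/C=C/c2ccc([N+](=O)[O-])cc2)O1`: 15400 nM
- Compound 3 `COc1ccc(/C=C/[C@@H]2CC=CC(=O)O2)cc1`: > 100000 nM, a limit

Compound 3 has no exact number, only the limit > 100000 nM. This is also the position of compound 1, and the shared ceiling is the limit of > 100000 nM in this assay, at which 2 of the 3 values shown sit.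

Compound 4 `O=C1C=CC[C@@H](/C=C/c2ccc([N+](=O)[O-])cc2)O1` has nitro in place of methoxy on an aromatic carbon of compound 3: nitro in place of methoxy on an aromatic carbon.

The same exchange has been measured once, as an at least 6.4-fold lower number from compound 1 to compound 2 (0.81 log units; beyond the scatter). That step lies beyond the scatter, and it is the main guide here. The other measured step, a step that the two limits leave unreadable from compound 1 to compound 3, gives no usable size for a change in configuration.

On the strength of an at least 6.4-fold lower number from compound 1 to compound 2 (0.81 log units; beyond the scatter), a clear drop to a lower number is expected for compound 4 in this assay, meaning a stronger inhibitor. Within the data shown here, with only one such exchange to go on, the expected size remains uncertain.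

The estimate amounts to an expected at least 6.6-fold lower number from compound 3 to compound 4 (0.82 log units; beyond the scatter).

For compound 4, the estimated value is 15000 nM, with an expected range from 4000 nM to 60000 nM.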

Compound 4, half-maximal inhibitory concentration: > 100000 nM
Compound 4: a limit, no number; the forecaster's own chance of this, stated with the estimate: 15%; at least 6.6-fold (0.82 log units) between middle value and limit.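

In this assay compound 4 gives only a limit of > 100000 nM and no exact number, so nitro in place of methoxy does not yield a measured potency when the saturated ring carbon is drawn S. The steps between the two methoxy compounds and from compound 3 to compound 4 cannot be read, as both ends of each are limits. Among these compounds, the new reading is an at least 6.4-fold higher number from compound 2 to compound 4 (0.81 log units; beyond the scatter) and it gives configuration a size for the first time, so the measurable activity of the nitro pair depends on the R drawing: the fact that compounds 2 and 4 differ only in the configuration as drawn.

Going by these compounds, this rests on a single readable pair, and how far compound 4 lies beyond its limit stays unknown. On these data alone, whether the R form would also give a number with another group at this place, such as an amine or a carboxylic acid, remains open.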